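The source may hold more compounds than are shown below. What is called first, only, known or untested is meant among the compounds shown, and "the series" means these compounds.

Compound 1: `CC(C)Oc1ccc(N2C[C@@H](C)N[C@@H](C)C2)cc1NS(=O)(=O)c1ccc(-c2ccccn2)s1` — in a functional assay for agonist activity at growth hormone secretagogue receptor type 1 (Homo sapiens), read by FLIPR (on this read-out lower numbers stand for an effect already at smaller amounts and higher numbers for an effect only at larger amounts of compound), compound 1 gives 100 nM
Compound 2: `COc1ccc(N2C[C@@H](C)N[C@@H](C)C2)cc1NS(=O)(=O)c1ccc(-c2ccncc2)cc1` — in this assay compound 2 gives 316 nM

Of the compounds shown here, two have been measured so far. Of the two, compound 2 stands at the higher number, and its distance from compound 1 lies beyond the scatter of repeated measurements; compound 1 therefore shows its effect at the smaller amount. Within the data shown here, the two structures differ in several places at once, so the measured pair gives no clean single-point step to lean on.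

Compound 3 is `COc1ccc(N2C[C@@H](C)N[C@@H](C)C2)cc1NS(=O)(=O)c1ccc(-c2ccc(C)o2)cc1`. It differs from compound 2 in one place: 5-methylfuran-2-yl in place of pyridin-4-yl on an aromatic carbon. One small aromatic ring thus replaces another of the same heavy-atom count, and the rest of the shared core is untouched. Among the measured compounds shown here, no measured pair shows what such a swap does in this assay, so the expectation rests on the observation that compound 2 already sits at the higher number and on the modest size of the change. The step from compound 2 to compound 3 is expected to be small, most likely within the scatter, with a slight lean toward a lower number, as a 1.3-fold lower number from compound 2 to compound 3 (0.10 log units; within the scatter) states. For compound 3 the estimate in this assay is 250 nM, in a range from 80 nM to 800 nM.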

Compound 3, half-maximal effective concentration: 0.794 nM
For compound 3 the middle estimate is 310-fold (2.50 log units) above the measured one, outside the stated range (below it).
By their numbers in this assay, from the lowest: compound 3; then compound 1; then compound 2.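

In this assay, putting 5-methylfuran-2-yl in place of pyridin-4-yl, on an aromatic carbon of a six-membered aromatic ring of carbon only, para to a large group, gives a 400-fold lower number from compound 2 to compound 3 (2.60 log units; beyond the scatter), so this position is far from indifferent to what sits on it. The two groups have the same heavy-atom count, each holds one hetero atom and one hydrogen-bond acceptor, and neither carries a net charge, so these shared counts alone do not settle the result at this position; what differs is the ring size, the hetero atom (oxygen for nitrogen) and the added methyl. No measurement at hand explains why this swap has so large an effect.

All three differences arrive together in this single step, so it remains open which of them, alone or in combination, accounts for the change. A plain furan-2-yl ring without the methyl would separate the methyl from the ring, and a 5-ethylfuran-2-yl group would test whether a longer chain at that spot keeps the low number.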